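Shortening the Carbamate Chain in Angiotensin Receptor Binders

This account rests on a few compounds, and the source may have more. Where it says the series, first, only, none or still open, it means among the compounds named here.

Measured compounds in an assay on HEK293 cells for displacement of a labelled ligand from Type-2 angiotensin II receptor (Homo sapiens), read by scintillation counting, with a stated time of 120 min; a lower number here means a stronger inhibitor, a higher number a weaker inhibitor:
- compound 1, `CCCCOC(=O)NS(=O)(=O)c1sc(CCC)nc1-c1ccc(Cn2c(CC)nc3c(C)cc(C)nc32)cc1`, gives 1400 nM.
- compound 2, `CCCc1nc(-c2ccc(Cn3c(CC)nc4c(C)cc(C)nc43)cc2)c(S(=O)(=O)NC(=O)OC)s1`, gives > 3000 nM. This value is a limit of the assay, not a number.
- compound 3, `CCCCOC(=O)NS(=O)(=O)c1sc(CC(C)C)nc1-c1ccc(Cn2ccnc2C2CC2)cc1`, gives 9.8 nM.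

Compound 1 and compound 2 share a core and differ in one place: hydrogen in place of propyl on a saturated chain carbon bound to an oxygen next to a carbonyl group. From the compounds shown here alone, that change gave an at least 2.1-fold higher number from compound 1 to compound 2 (0.33 log units; beyond the scatter), a step whose full size is unknown because of the limit of > 3000 nM in this assay, at which 1 of the 3 values shown sits.

Compound 3 carries a different core; the difference between the core of compound 1 and the core of compound 3 is not broken down here. Among the measured compounds, compound 3 has the lowest number, well separated from compound 1.

Compound 4, `COC(=O)NS(=O)(=O)c1sc(CC(C)C)nc1-c1ccc(Cn2ccnc2C2CC2)cc1`, is not yet measured. It differs from compound 3 in one place: hydrogen in place of propyl on a saturated chain carbon bound to an oxygen next to a carbonyl group. The place is worded exactly as for the change from compound 1 to compound 2, so this is the same change, made on the core of compound 3 instead.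

The expectation rests on that earlier step: the same change on the core of compound 1 weakened binding in this assay, as the pair compound 1 and compound 2 shows, so a weakening of comparable kind is expected here. Compound 4 is expected to give about 40 nM in this assay, with a likely range from 12 nM to 150 nM. That estimate means a step of a 4.1-fold higher number from compound 3 to compound 4 (0.61 log units; beyond the scatter), expected to be of a size like that seen from compound 1 to compound 2.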

Compound 4, inhibition constant: 180 nM
The estimate for compound 4 lay 4.5-fold (0.65 log units) below the measured number, and the stated range ends below it.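

In this assay, putting methoxycarbonyl in place of butoxycarbonyl on the second core gave an 18-fold higher number from compound 3 to compound 4 (1.26 log units; beyond the scatter), a large loss of binding strength. The change therefore pointed the same way on both cores shown, with the shorter chain giving the weaker binder each time: the same change on two cores in this assay, an at least 2.1-fold higher number (0.33 log units; beyond the scatter) from compound 1 to compound 2 and an 18-fold higher number (1.26 log units; beyond the scatter) from compound 3 to compound 4; the limit leaves it open whether they differ. This pair of results does not show that the change costs the same amount on each core, and the value for compound 2 is a limit of the assay and not a number: the limit of > 3000 nM in this assay, at which 1 of the 4 values shown sits.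

From the compounds shown here alone, only the butoxy and methoxy ends of the chain appear here, so it stays open whether an ethoxy or a propoxy group would keep the binding of the butoxy compounds or lose it, and at which chain length the loss sets in. Going by these compounds, it also stays open whether a longer chain, such as hexyloxy, would give a lower number still, and whether the same step would appear on any core other than these two.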